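The compounds below may be only part of what the source reports. "The series", "measured", "known", "first", "only" and "open" are said of these compounds alone.

Compound 1, `CCCCCc1ccc(Nc2cccc3c2C(=O)N(C2CCC(=O)NC2=O)C3=O)cc1`: in an assay on FRT-Jurkat cells for inhibition of nuclear factor NF-kappa-B complex (Homo sapiens), read by flow cytometry, with a stated time of 24 h, tested at 10 uM (a lower number here means less inhibition, a higher number more inhibition at the concentration tested (going by the name of the read-out)), compound 1 gives 23%.
Compound 2, `O=C1CCC(N2C(=O)c3cccc(Nc4ccc(O)cc4)c3C2=O)C(=O)N1`: in this assay compound 2 gives 4%.

Among the compounds with values here, compound 2 holds the lower of the two numbers; the only measured step, a number 19 percentage points lower from compound 1 to compound 2 (beyond the scatter), separates it from compound 1. Compound 3, `CCCc1ccc(Nc2cccc3c2C(=O)N(C2CCC(=O)NC2=O)C3=O)cc1`, takes the change (propyl in place of hydroxy on an aromatic carbon). This runs the measured step in the opposite direction, from hydroxy back to a chain, though a shorter one than the pentyl of compound 1. A rise beyond the scatter is therefore expected, of size a number 11 percentage points higher from compound 2 to compound 3 (beyond the scatter), landing between the two measured values. Compound 3 is estimated at 15%, within 3% to 27%.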

Compound 3, a percentage reported as inhibition, at one concentration (the size of the read-out at that concentration, not a potency): 23%
Estimate against measurement, compound 3: 8 percentage points below; the measured number falls inside the stated range.
By their numbers in this assay, from the lowest: compound 2; then compounds 1 and 3 (each within the scatter of the next).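

Restoring a chain at this position, with propyl in place of hydroxy, gives a number 19 percentage points higher from compound 2 to compound 3 (beyond the scatter), so the low number of compound 2 goes with hydroxy and not with the shared core. The chain's length matters little across this pair, with no change at the digits printed from compound 1 to compound 3 (within the scatter), so propyl and pentyl cannot be told apart in this assay. Still open, going by these compounds, is whether a methyl, a much longer chain, an amine or a carboxylic acid here would read like these two chains or like hydroxy. No measurement at hand explains the difference between hydroxy and the chains.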